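Replacing tert-butyl with 1-phenylethyl on compound 2

A few compounds are considered here, and "the series" means these few. Any claim that something is new, unique, unknown or untested is made for them only; others in the source may bear on it.

Of the compounds shown here, two have been measured in a functional assay for inhibition, with Rattus norvegicus as the target; a higher number here means a weaker inhibitor, a lower number a stronger inhibitor. Compound 1 `COc1ccc(Nc2c(NC(C)C(C)(C)C)c(=O)c2=O)cc1` gives 2400 nM in this assay. Compound 2 `CC(C)(C)/N=c1\c(O)c(O)\c1=N/c1ccc(C#N)cc1` gives 560 nM in this assay, the lower of the two numbers, and its nearest neighbour is compound 1, whose number is higher by a margin beyond the usual scatter. Among the measured compounds shown here, the two differ in more than one place, so no single structural step between them can be read from their values.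

Compound 3 `C[C@@H](/N=c1\c(O)c(O)\c1=N/c1ccc(C#N)cc1)c1ccccc1` is not yet measured. It differs from compound 2 in one place: 1-phenylethyl in place of tert-butyl on a double-bonded nitrogen. For the measured compounds named here, no measured pair shows this change, so its effect has to be guessed. Since compound 2 already gives 560 nM, the step from compound 2 to compound 3 is expected to be small, a 1.1-fold lower number from compound 2 to compound 3 (0.05 log units; within the scatter), with no clear direction beyond the scatter. Compound 3 is therefore expected to give about 500 nM in this assay, with a plausible range from 150 nM to 2000 nM.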

Compound 3, half-maximal inhibitory concentration: 56 nM
Beside the measured number, compound 3's estimate is 8.9-fold (0.95 log units) above it; measured number below the stated range.
By their numbers in this assay, from the lowest: compound 3; then compound 2; then compound 1.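

In this assay, putting 1-phenylethyl in place of tert-butyl on a double-bonded nitrogen gives a 10-fold lower number from compound 2 to compound 3 (1.00 log units; beyond the scatter), the first single-place step available in this series, and it shows that the group at this position can shift the number well beyond the scatter. The entering group differs from tert-butyl in several ways at once, bringing more heavy atoms, a six-membered aromatic ring of carbon only and a defined stereocentre, so this one step cannot assign the drop to any single one of these features. Nothing available here bears on the reason for the step.

As far as these compounds go, it remains open what a benzyl group, the opposite enantiomer of 1-phenylethyl or a 1-cyclohexylethyl group would do at this nitrogen, and comparisons with these would help separate the contributions of the ring, the branching and the stereocentre. From the compounds shown here alone, it is also open whether a step of similar size would appear with a methoxy group in place of the nitrile on the other side of the shared core.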